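A few compounds are considered here, and "the series" means these few. Any claim that something is new, unique, unknown or untested is made for them only; others in the source may bear on it.

Three compounds share one core, differing in the group attached to the saturated chain carbon that hangs off that core. Compound 1 `CN(Cc1ccccc1)C(=O)c1cc2c(Cc3cccc(Cl)c3)n[nH]c2cc1O` carries a 3-chlorobenzyl there, and in a functional assay on A2780 cells (Homo sapiens) for antiproliferative activity, read by resazurin assay, with a stated time of 72 h (a higher number here means a weaker inhibitor, a lower number a stronger inhibitor), compound 1 gives 410 nM. Compound 2 `COc1cccc(Cc2n[nH]c3cc(O)c(C(=O)N(C)Cc4ccccc4)cc23)c1` carries a 3-methoxybenzyl instead; in this assay compound 2 gives "not determined" (no result reported), so no number marks where compound 2 stands, and the only measured point of reference is compound 1. Compound 3 `CCc1ccc(Cc2n[nH]c3cc(O)c(C(=O)N(C)Cc4ccccc4)cc23)cc1` is the next step, and from compound 2 to compound 3 the change is 4-ethylphenyl in place of 3-methoxyphenyl on a saturated chain carbon bound to an aromatic carbon. Within the data shown here, with no measured pair of this kind to go by, the change from compound 2 to compound 3 is expected to shift the result in this assay by no more than the scatter in either direction, leaving compound 3 near the value seen for compound 1. On that basis compound 3 is estimated at 600 nM in this assay, within a range from 150 nM to 2500 nM.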

Compound 3, half-maximal inhibitory concentration: > 10000 nM
Compound 3 ended at the assay's limit; the forecaster's own chance of this, stated with the estimate: 5%; middle value at least 16-fold (1.22 log units) away from the limit.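

In this assay compound 3 gives > 10000 nM, which is a limit of the assay and not a number. The group on the saturated chain carbon clearly matters in this pair: the change to 4-ethylphenyl from 3-chlorophenyl gives an at least 24-fold higher number from compound 1 to compound 3 (1.38 log units; beyond the scatter), so these two groups are not interchangeable at this place. This is the first sign that a change here can carry a compound out of the assay's measurable range: the limit of > 10000 nM in this assay, at which 1 of the 3 values shown sits.

Among these compounds, no step to or from compound 2 can be read, so the effect of 3-methoxyphenyl stays open. On these data alone, it also remains open whether the ethyl in place of the chlorine or the move from the 3-substituted to the 4-substituted ring counts more, a question that 4-chlorobenzyl or 3-ethylbenzyl at this place could separate.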